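Aryl change from compound 1 to compound 4

The source may hold more compounds than are shown below. What is called first, only, known or untested is meant among the compounds shown, and "the series" means these compounds.

Measured so far:
compound 1 `CC(C)[C@H](NC(=O)CCN(C)C)c1cccc(F)c1N1CCN(C(=O)[C@@H]2CN(C(C)C)C[C@H]2c2ccc(C(F)(F)F)cc2F)CC1`: 61 nM
compound 2 `Cc1ccc(N2CCN(C(=O)[C@@H]3CN(C4CCOCC4)C[C@H]3c3ccc(Cl)cc3)CC2)c([C@@H](NC(=O)CCN)C(C)C)c1`: 2.2 nM
compound 3 `Cc1ccc(N2CCN(C(=O)[C@@H]3CNC[C@H]3c3ccc(Cl)cc3)CC2)c([C@@H](NC(=O)CCN(C)C)C(C)C)c1`: 7.2 nM

In an assay on HEK293 cells for displacement of a labelled ligand from Melanocortin receptor 4 (Homo sapiens) (a higher number here means a weaker inhibitor, a lower number a stronger inhibitor), compound 1 shows the highest number of the three; the nearest, compound 3, sits lower by a gap beyond the scatter, and compound 2 lies further below. No pair among these differs in one place, so compound 2 and compound 3 speak only through their own values and give no measured step that isolates any single change.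

Compound 4 `CC(C)[C@H](NC(=O)CCN(C)C)c1cccc(F)c1N1CCN(C(=O)[C@@H]2CN(C(C)C)C[C@H]2c2cc(F)c(F)c(F)c2)CC1` differs from compound 1 by 3,4,5-trifluorophenyl in place of 2-fluoro-4-(trifluoromethyl)phenyl on a saturated ring carbon. Nothing measured bears on this change directly, so the step from compound 1 to compound 4 is expected to be a 1.3-fold higher number from compound 1 to compound 4 (0.12 log units; within the scatter), none beyond the scatter, with the direction open. Compound 4 is estimated at 80 nM, within 30 nM to 250 nM.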

Compound 4, inhibition constant: 250 nM
For compound 4 the middle estimate is 3.1-fold (0.49 log units) below the measured one; measured number inside the range.
By their numbers in this assay, from the lowest: compound 2; then compound 3; then compound 1; then compound 4.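

In this assay the aryl group on the saturated ring carbon matters: 3,4,5-trifluorophenyl in place of 2-fluoro-4-(trifluoromethyl)phenyl gives a 4.1-fold higher number from compound 1 to compound 4 (0.61 log units; beyond the scatter) on the otherwise unchanged core of compound 1. This is the only single-place step shown, and it lies beyond the scatter. Nothing available here accounts for the step.

On these data alone, the two aryl groups differ in several substituents at once, so which difference carries the step stays open. As far as these compounds go, how a nitrile or a methoxy group on this aryl ring would read in this assay also remains open.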